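Removing the Ring Chlorine a Second Time

The source may hold more compounds than are shown below. What is called first, only, known or untested is meant among the compounds shown, and "the series" means these compounds.

Of the compounds shown here, three have been measured in a functional assay on NCI-H460 cells (Homo sapiens) for antiproliferative activity, read by MTT assay, with a stated time of 48 h; on this read-out lower numbers stand for stronger inhibition and higher numbers for weaker inhibition. Compound 1 `O=C(CCCl)Nc1ccc(SCC(=O)Nc2cc(Cl)ccn2)cc1` gives 10900 nM. Compound 2 `O=C(CCCl)Nc1ccc(SCC(=O)Nc2ccccn2)cc1` gives 65400 nM in this assay, and compound 3 `C=CC(=O)Nc1ccc(SCC(=O)Nc2cc(Cl)ccn2)cc1` gives 19700 nM.

Compound 2 differs from compound 1 by hydrogen in place of chloro on an aromatic carbon. That single change produced a step of a 6.0-fold higher number from compound 1 to compound 2 (0.78 log units; beyond the scatter). Compound 3 differs from compound 1 by vinyl in place of 2-chloroethyl on a carbonyl carbon, and here the step was a 1.8-fold higher number from compound 1 to compound 3 (0.26 log units; within the scatter), so these two compounds cannot be ranked against each other.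

Compound 4 `C=CC(=O)Nc1ccc(SCC(=O)Nc2ccccn2)cc1` has not yet been measured. It differs from compound 3 by hydrogen in place of chloro on an aromatic carbon. This is the same change that separates compound 1 from compound 2, made at the same place, and it occurs twice among the four compounds. The two cores on which the change is made differ from each other only in the way already described for compound 3 against compound 1.

Because the same change earlier gave a 6.0-fold higher number from compound 1 to compound 2 (0.78 log units; beyond the scatter), compound 4 is expected to show a step of a 6.0-fold higher number from compound 3 to compound 4 (0.78 log units; beyond the scatter) in this assay. A single earlier example is a thin basis, and whether the step carries over unchanged to the core that carries the vinyl group is not known. The estimate for compound 4 is 118000 nM, with a likely range from 55000 nM to 260000 nM.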

Compound 4, half-maximal inhibitory concentration: 76800 nM
For compound 4 the middle estimate is 1.5-fold (0.19 log units) above the measured one; measured number inside the range.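

Going from 4-chloropyridin-2-yl to pyridin-2-yl on the core that carries the vinyl group gave a 3.9-fold higher number from compound 3 to compound 4 (0.59 log units; beyond the scatter) in this assay, and this step agrees with the one seen on the core that carries the 2-chloroethyl group: the same change on two cores in this assay, a 6.0-fold higher number (0.78 log units; beyond the scatter) from compound 1 to compound 2 and a 3.9-fold higher number (0.59 log units; beyond the scatter) from compound 3 to compound 4, 1.5-fold (0.19 log units) apart, within the scatter of two such steps. The other change behaves the same way, since vinyl in place of 2-chloroethyl on the core without the ring chlorine gave a 1.2-fold higher number from compound 2 to compound 4 (0.07 log units; within the scatter), so compound 2 and compound 4 cannot be ranked against each other, and this small step matches the earlier one: the same change on two cores in this assay, a 1.8-fold higher number (0.26 log units; within the scatter) from compound 1 to compound 3 and a 1.2-fold higher number (0.07 log units; within the scatter) from compound 2 to compound 4, 1.5-fold (0.19 log units) apart, within the scatter of two such steps. Within these four compounds, then, each change had about the same size on both cores, but this rests on only one pair of cores and does not show that the loss on removing the chlorine would carry over to a core that differs elsewhere, nor does it explain why the chlorine matters.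

Only chloro and hydrogen are shown at the ring position opposite the ring nitrogen, so it remains open how a methyl group or an amine there would compare. Going by these compounds, it is also open whether a longer chain in place of the 2-chloroethyl or vinyl group on the carbonyl would follow the same pattern.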